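Thiazole aryl swap in a phenoxymethyl benzofuran acid series

This account rests on a few compounds, and the source may have more. Where it says the series, first, only, none or still open, it means among the compounds named here.

Two compounds of the series have a number in a functional assay on CHO cells for agonist activity at Free fatty acid receptor 1 (Homo sapiens), read by FLIPR and calcium flux, tested at 100 nM; a higher number here means a stronger effect of the compound at the concentration tested, a lower number a weaker effect. Compound 1 `O=C(O)CC1COc2cc(OCc3nc(-c4ccccc4)cs3)ccc21` gives 0.16% in this assay. Compound 2 `Cc1nc(-c2ccsc2)sc1COc1ccc2c(c1)OCC2CC(=O)O` gives 56.5% in this assay; this is the highest of the two numbers, and the nearest, compound 1, lies beyond the scatter below it. Going by the values given here, no step between two measured compounds that differ in one place is available.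

Compound 3 `Cc1nc(-c2cccc(Cl)c2)sc1COc1ccc2c(c1)OCC2CC(=O)O` has not been measured in this assay. It differs from compound 2 in one place: 3-chlorophenyl in place of thiophen-3-yl on an aromatic carbon. Compound 1 carries a plain phenyl at the same ring atom and lacks the methyl group, so it gives no direct read on this change.

Given the distance from compound 2 to compound 1, compound 3 is expected to keep part of the activity of compound 2, with an estimated step of a number 11.5 percentage points lower from compound 2 to compound 3 (beyond the scatter) in this assay. For compound 3 the estimate in this assay is 45%, with a range from 10% to 80%.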

Compound 3, a percentage reported as activity, at one concentration (the size of the read-out at that concentration, not a potency): 43%
The estimate for compound 3 lay 2 percentage points above the measured number; the range from low to high includes it.
By their numbers in this assay, from the lowest: compound 1; then compound 3; then compound 2.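

On the aromatic carbon next to the ring nitrogen and next to the ring sulfur, 3-chlorophenyl in place of thiophen-3-yl gives a number 13.5 percentage points lower from compound 2 to compound 3 (beyond the scatter) in this assay. This position therefore tolerates a six-membered aromatic ring of carbon only with a modest loss, and the sulfur of thiophen-3-yl is not needed for compound 3 to keep a clear read-out at the concentration tested. No measurement shown gives a reason for this step.

The change swaps the ring and adds chlorine at once, so the share of each in the step cannot be separated. A plain phenyl on the core of compound 2 would separate them, and a pyridine ring or a 3-methoxyphenyl at this position remains an open comparison.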